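The compounds below may be only part of what the source reports. "The series", "measured", "known", "first", "only" and "open" are said of these compounds alone.

Measured in a functional assay on HCC827 cells (Homo sapiens) for antiproliferative activity, read by MTT assay, with a stated time of 72 h; a higher number here means a weaker inhibitor, a lower number a stronger inhibitor:
Compound 1 `CN1CCN(c2ccc(Nc3ncc4nc([S+]([O-])c5ccccc5)n([C@H]5CC[C@H](O)CC5)c4n3)cc2)CC1`: 268 nM
Compound 2 `CN(C)C1CCN(c2ccc(Nc3ncc4nc([S+]([O-])c5ccccc5)n(C5CCOCC5)c4n3)cc2)CC1`: 1290 nM

Of these two compounds, compound 2, at 1290 nM, has the higher number and is the weaker inhibitor, beyond the scatter. Compound 3 `CN1CCC(Oc2ccc(Nc3ncc4nc([S+]([O-])c5ccccc5)n(C5CCOCC5)c4n3)cc2)CC1` carries (1-methylpiperidin-4-yl)oxy in place of 4-(dimethylamino)piperidin-1-yl on an aromatic carbon, para to a large group ((1-methylpiperidin-4-yl)oxy in place of 4-(dimethylamino)piperidin-1-yl on an aromatic carbon). Within the data shown here, no measured pair of compounds shows this change, so only a small shift toward a lower number is expected in this assay, none beyond the scatter. The expected step is a 1.4-fold lower number from compound 2 to compound 3 (0.16 log units; within the scatter). For compound 3 the estimated value is 900 nM, with an expected range of 300 nM to 2700 nM.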

Compound 3, half-maximal inhibitory concentration: 853 nM
For compound 3 the middle estimate is 1.1-fold (0.02 log units) above the measured one; the range from low to high includes it.
By their numbers in this assay, from the lowest: compound 1; then compounds 3 and 2 (each within the scatter of the next).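

In this assay, (1-methylpiperidin-4-yl)oxy in place of 4-(dimethylamino)piperidin-1-yl on the aromatic carbon gives a 1.5-fold lower number from compound 2 to compound 3 (0.18 log units; within the scatter). Among these compounds, this is the first pair differing only at this position, and it shows that these two large groups cannot be told apart here, although one is attached through oxygen and the other through a ring nitrogen. No supporting measurement bears on this result. As far as these compounds go, it remains open whether a morpholine ring or a primary amine at this position would read alike. From the compounds shown here alone, it also remains open whether this exchange would give a similar step on the core of compound 1.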